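Notes on compound 4: carboxy in place of hydroxymethyl

This account rests on a few compounds, and the source may have more. Where it says the series, first, only, none or still open, it means among the compounds named here.

The series is read in a functional assay on HCT-116 cells (Homo sapiens) for inhibition, read by sulforhodamine B assay, with a stated time of 48 h; a lower number here means a stronger inhibitor, a higher number a weaker inhibitor. Compound 1 `C=CCC(O)(c1ccc(OC)c(OC)c1OC)c1cccc2ccccc12` reaches only the limit of the assay, reported for compound 1 as > 20000 nM. Compound 3 `COc1ccc(/C(=C\c2ccc(F)cc2)c2cccc3ccccc23)c(OC)c1OC` likewise sits at the limit, compound 3 giving > 20000 nM. Compound 2 `COc1ccc(C(c2ccc(OCCO)cc2)c2cccc3ccccc23)c(OC)c1OC` stands at the same limit, compound 2 giving > 20000 nM. Every number shown so far is therefore a limit and not a measured value, namely (the limit of > 20000 nM in this assay, at which 3 of the 3 values shown sit); compound 2 cannot be ranked against compounds 1 and 3 beyond the fact that all three share that limit.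

Compound 4 `COc1ccc(C(c2ccc(OCC(=O)O)cc2)c2cccc3ccccc23)c(OC)c1OC` differs from compound 2 in one place: carboxy in place of hydroxymethyl on a saturated chain carbon bound to an oxygen on an aromatic ring. Among the compounds with values here, no step between two measured compounds exists in this set, so the size of such a change cannot be read from the series itself. The expectation for compound 4 is no shift beyond the scatter, the step from compound 2 to compound 4 being estimated at a step that the limit leaves unreadable from compound 2 to compound 4. Compound 4 is expected at 25000 nM, with a range from 8000 nM to 80000 nM, and most probably it will again be reported only as a limit.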

Compound 4, half-maximal inhibitory concentration: 5020 nM
Compound 4: middle estimate off by 5.0-fold (0.70 log units), on the high side, outside the stated range (below it).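

In this assay, within the data shown here, carboxy in place of hydroxymethyl gives an at least 3.9-fold lower number from compound 2 to compound 4 (0.60 log units; beyond the scatter) and so shows that this position, on a saturated chain carbon bound to an oxygen on an aromatic ring, responds to a change of group, which the earlier compounds could not show. Among these compounds, compound 4 is also the only compound so far with a measured value rather than a limit, giving the series its first fixed point. The full size of the step stays unknown because compound 2 carries only a limit: the limit of > 20000 nM in this assay, at which 3 of the 4 values shown sit.

Going by these compounds, whether the gain is specific to carboxy remains open, since a methyl ester, a primary amide or an amine at the end of the same chain would be needed to test this. On these data alone, a longer chain between the ring oxygen and the carboxy group also remains untested here.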